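Urea aryl swap on a shared core

The compounds below may be only part of what the source reports. "The series", "measured", "known", "first", "only" and "open" are said of these compounds alone.

Compound 1: `COc1cc(Cl)cc(-c2nn(-c3cccc(NC(=O)Nc4cc(C(F)(F)F)cc(C(F)(F)F)c4)c3)cc2-c2ccncc2)c1` gives -84% in a functional assay on NCI-H460 cells (Homo sapiens) for inhibition, read by sulforhodamine B assay, with a stated time of 48 h, tested at 100 uM; a higher number here means a weaker effect of the compound at the concentration tested, a lower number a stronger effect.
Compound 2: `COc1cc(Cl)cc(-c2nn(-c3cccc(NC(=O)Nc4ccc(Cl)c(Cl)c4)c3)cc2-c2ccncc2)c1` gives -8% in this assay.

Compound 2 stands highest of the two numbers in this assay, with compound 1 far lower, beyond the scatter. Compound 3, `COc1cc(Cl)cc(-c2nn(-c3cccc(NC(=O)Nc4cccc(C(F)(F)F)c4)c3)cc2-c2ccncc2)c1`, differs from compound 2 in one place: 3-(trifluoromethyl)phenyl in place of 3,4-dichlorophenyl on an amide-type nitrogen. Within the data shown here, no measured pair isolates this exchange. Compound 1 carries two trifluoromethyl groups on its urea aryl and gives -84%, so a step downward from compound 2 is expected, of size a number 32 percentage points lower from compound 2 to compound 3 (beyond the scatter), though its extent is uncertain. For compound 3 the estimate is -40%, within -85% to 5%.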

Compound 3, a percentage reported as activity, at one concentration (the size of the read-out at that concentration, not a potency): -48%
Compound 3: middle estimate off by 8 percentage points, on the high side; the range from low to high includes it.
By their numbers in this assay, from the lowest: compound 1; then compound 3; then compound 2.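

In this assay, 3-(trifluoromethyl)phenyl in place of 3,4-dichlorophenyl on the amide-type nitrogen gives a number 40 percentage points lower from compound 2 to compound 3 (beyond the scatter), so this exchange alone moves the read-out. Hydrogen in place of trifluoromethyl on an aromatic carbon gives a number 36 percentage points higher from compound 1 to compound 3 (beyond the scatter), so the second trifluoromethyl also counts, while compound 3 keeps part of the effect of compound 1. Nothing available explains either step.

As far as these compounds go, whether an amine or a carboxylic acid in place of trifluoromethyl on this aryl ring would move the read-out in the same direction remains open.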